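A few compounds are considered here, and "the series" means these few. Any claim that something is new, unique, unknown or untested is made for them only; others in the source may bear on it.

Three compounds built on a shared core have been run in a functional assay on MDA-MB-231 cells (Homo sapiens) for inhibition, read by MTT assay, with a stated time of 24 h, tested at 100 uM; on this read-out higher numbers stand for more inhibition at the one concentration tested (going by the name of the read-out) and lower numbers for less inhibition. Compound 1 `O=C(N/N=C/c1ccc(F)cc1)c1ccc(O[C@@H]2O[C@H](CO)[C@@H](O)[C@H](O)[C@H]2O)cc1` gives 9.91%. Compound 2 `N#Cc1cccc(/C=N/NC(=O)c2ccc(O[C@@H]3O[C@H](CO)[C@@H](O)[C@H](O)[C@H]3O)cc2)c1` gives 6.17%, and compound 3 `O=C(N/N=C/c1ccc(Cl)cc1)c1ccc(O[C@@H]2O[C@H](CO)[C@@H](O)[C@H](O)[C@H]2O)cc1` gives 2.26%. Compound 3 sits with the other two inside the usual scatter: a number 3.9 percentage points lower from compound 2 to compound 3 (within the scatter) and a number 7.7 percentage points lower from compound 1 to compound 3 (within the scatter). Compound 4 `O=C(N/N=C/c1cccc([N+](=O)[O-])c1)c1ccc(O[C@@H]2O[C@H](CO)[C@@H](O)[C@H](O)[C@H]2O)cc1` differs from compound 3 in one place: 3-nitrophenyl in place of 4-chlorophenyl on a carbon with a double bond to nitrogen. Among the measured compounds shown here, two measured steps bear on this change, the move to a 3-cyanophenyl, a number 3.7 percentage points lower from compound 1 to compound 2 (within the scatter), and the move from it to a 4-chlorophenyl, a number 3.9 percentage points lower from compound 2 to compound 3 (within the scatter), both within the scatter. No step beyond the scatter is therefore expected in this assay. Compound 4 is estimated at 6%, with a range from 0% to 16%. The expected step of a number 3.7 percentage points higher from compound 3 to compound 4 (within the scatter) is within the scatter.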

Compound 4, a percentage reported as inhibition, at one concentration (the size of the read-out at that concentration, not a potency): 6.23%
The estimate for compound 4 lay 0.2 percentage points below the measured number; the range from low to high includes it.
By their numbers in this assay, from the lowest: compounds 3, 2, 4 and 1 (each within the scatter of the next).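

In this assay, 3-nitrophenyl on the carbon with a double bond to nitrogen stays within the scatter of all three earlier groups: a number 4 percentage points higher from compound 3 to compound 4 (within the scatter), a number 0.1 percentage points higher from compound 2 to compound 4 (within the scatter) and a number 3.7 percentage points lower from compound 1 to compound 4 (within the scatter). Among the compounds shown here, the nitro group, with its 2 hydrogen-bond acceptors, thus extends to a fourth aromatic group a set in which no step at this position exceeds the scatter. Nothing available explains these small differences. As far as these compounds go, whether an aminophenyl group, a carboxyphenyl group or a longer alkyl chain on this carbon would give a step beyond the scatter remains open.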